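The source may hold more compounds than are shown below. What is called first, only, known or untested is meant among the compounds shown, and "the series" means these compounds.

Compound 2, `CC(C)c1nn(-c2ccc(C(N)=O)c(N[C@H]3CC[C@H](O)CC3)c2)c2nccc(-n3cnc(-c4ccncc4)c3)c12`, gives 165 nM in a functional assay on SK-BR-3 cells (Homo sapiens) for inhibition, read by CellTiter-Glo, with a stated time of 72 h; a lower number here means a stronger inhibitor, a higher number a weaker inhibitor. It holds the lower of the two numbers recorded: its only companion, compound 1, `CNc1cc(-n2nc(C(C)C)c3c(-n4cnc(-c5cnn(C)c5)c4)ccnc32)ccc1C(N)=O`, gives 773 nM in this assay, a gap wide enough to sit beyond the usual scatter of repeated measurements. Among the compounds with values here, compound 1 and compound 2 differ in more than one place, so no single step between them can be read off.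

Compound 3, `COc1ccc(-c2cn(-c3ccnc4c3c(C(C)C)nn4-c3ccc(C(N)=O)c(N[C@H]4CC[C@H](O)CC4)c3)cn2)cc1`, has not yet been measured in this assay. It is separated from compound 2 by one change, (4-methoxyphenyl in place of pyridin-4-yl on an aromatic carbon). The rest of the molecule, including the group bearing the primary amide and the hydroxy-substituted cyclohexyl amine, is the same in both.

Within the data shown here, nothing among the measured compounds isolates the effect of swapping the pyridin-4-yl for the 4-methoxyphenyl, so the expectation leans on compound 2 alone. The step from compound 2 to compound 3 is expected to be a 1.7-fold higher number from compound 2 to compound 3 (0.23 log units; within the scatter), a shift that would stay within the scatter or at most edge slightly toward weaker inhibition. Compound 3 is therefore estimated to give 280 nM in this assay, with a plausible range from 80 nM to 1000 nM.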

Compound 3, half-maximal inhibitory concentration: 256 nM
Compound 3: middle estimate off by 1.1-fold (0.04 log units), on the high side; the range from low to high includes it.
By their numbers in this assay, from the lowest: compounds 2 and 3 (each within the scatter of the next); then compound 1.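

In this assay, putting 4-methoxyphenyl in place of pyridin-4-yl on this aromatic carbon of the five-membered ring gives a 1.6-fold higher number from compound 2 to compound 3 (0.19 log units; within the scatter), so the two compounds cannot be told apart. Within the data shown here, this is the first direct reading at this position, and it shows that, with the rest of compound 2 held fixed, a six-membered aromatic ring of carbon only serves here as well as one with a ring nitrogen, even though the entering group is the larger of the two. No measurement shown gives a reason for this tolerance, and the single pair offers no explanation of its own.

What the compounds leave open is how far this tolerance reaches, as one swap cannot separate the contribution of the methoxy group from that of the phenyl ring, and a plain phenyl, or a phenyl carrying a carboxylic acid or an amine, would test this. Going by these compounds, the same change on the amine of compound 1 also remains unknown, so it cannot be said whether the result holds beyond the hydroxy-substituted cyclohexyl amine.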